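This account rests on a few compounds, and the source may have more. Where it says the series, first, only, none or still open, it means among the compounds named here.

For the measured compounds named here, compound 1 `CC1(C)CNC(=O)c2sc(Nc3ccc(I)cc3Cl)c(C(=O)NOC[C@H](O)CO)c2C1` is the weakest inhibitor among the three measured members: in a functional assay on HT-29 cells (Homo sapiens) for antiproliferative activity (on this read-out higher numbers stand for weaker inhibition and lower numbers for stronger inhibition), compound 1 gives 896 nM, the highest of the three numbers. Compound 2 `CC1(C)CNC(=O)c2sc(Nc3ccc(I)cc3Cl)c(C(N)=O)c2C1` gives 596 nM, and compound 3 `CC(C)(N)CNC(=O)c1c(Nc2ccc(I)cc2Cl)sc2c1CC(C)(C)CNC2=O` gives 113 nM. The measured steps all concern the amide-type nitrogen: a 1.5-fold lower number from compound 1 to compound 2 (0.18 log units; within the scatter), a 7.9-fold lower number from compound 1 to compound 3 (0.90 log units; beyond the scatter) and a 5.3-fold lower number from compound 2 to compound 3 (0.72 log units; beyond the scatter).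

Compound 4 `CC1(C)CNC(=O)c2sc(Nc3ccc(I)cc3F)c(C(=O)NOC[C@H](O)CO)c2C1` differs from compound 1 at another place: fluoro in place of chloro on an aromatic carbon. Going by the values given here, no measured step touches the halogen on the anilino ring; the three steps above change the amide nitrogen substituent and say nothing about this exchange. With no comparison to lean on, the step from compound 1 to compound 4 is expected to stay within the scatter, and the estimated step is a 1.1-fold higher number from compound 1 to compound 4 (0.05 log units; within the scatter). For compound 4 in this assay the expected value is therefore 1000 nM, with a range from 400 nM to 2500 nM reflecting the absence of any measured halogen exchange in the series.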

Compound 4, half-maximal inhibitory concentration: 1580 nM
For compound 4 the middle estimate is 1.6-fold (0.20 log units) below the measured one, and the stated range covers the measured number.
By their numbers in this assay, from the lowest: compound 3; then compounds 2, 1 and 4 (each within the scatter of the next, the first and the last beyond it).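

In this assay, the exchange from 2-chloro-4-iodophenyl to 2-fluoro-4-iodophenyl gives a 1.8-fold higher number from compound 1 to compound 4 (0.25 log units; within the scatter), the only reading shown for a change away from the amide-type nitrogen. At this aromatic carbon, with 2,3-dihydroxypropoxy on the amide-type nitrogen, chloro and fluoro therefore cannot be told apart, whereas 2-amino-2-methylpropyl at that nitrogen gives a 7.9-fold lower number from compound 1 to compound 3 (0.90 log units; beyond the scatter). No available evidence bears on this reading.

Open, as far as these compounds go, is whether the same halogen exchange also stays within the scatter when 2-amino-2-methylpropyl sits on the amide-type nitrogen. Also open, from the compounds shown here alone, is how a bromo or methyl group at this aromatic carbon, or an ethynyl group in place of the iodo group, would read in this assay.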